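This account rests on a few compounds, and the source may have more. Where it says the series, first, only, none or still open, it means among the compounds named here.

Working notes on the series.

Compound 1 `COc1ccc(NC(=O)COc2c(-c3ccccc3)oc3ccccc3c2=O)cc1` and compound 3 `COc1ccc(NC(=O)COc2ccc3c(=O)c(-c4ccccc4)coc3c2)cc1` share the same atoms joined differently; the difference between the two cores is not broken down here. In a functional assay on NCI-H661 cells (Homo sapiens) for antiproliferative activity, read by MTT assay, with a stated time of 72 h (on this read-out higher numbers stand for weaker inhibition of growth and lower numbers for stronger inhibition of growth), compound 1 gives 6740 nM. In this assay compound 3 gives 9530 nM, which stands within the scatter of compound 1.

Compound 2 `O=C(COc1c(-c2ccccc2)oc2ccccc2c1=O)Nc1ccc(-c2ccccc2)cc1` carries the change phenyl in place of methoxy on an aromatic carbon relative to compound 1. In this assay compound 2 returns only a limit, > 10000 nM, the limit of the assay described as the limit of > 10000 nM in this assay, at which 1 of the 3 values shown sits. The step of an at least 1.4-fold higher number from compound 1 to compound 2 (0.17 log units; that floor lies within the scatter) is therefore a floor, and its true size is open.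

Compound 4 `O=C(COc1ccc2c(=O)c(-c3ccccc3)coc2c1)Nc1ccc(-c2ccccc2)cc1` is the unmeasured partner of compound 3, carrying the change (phenyl in place of methoxy on an aromatic carbon); this is the same change as from compound 1 to compound 2, with the same surroundings at the place of the change. For compound 4 a step of a 1.7-fold higher number from compound 3 to compound 4 (0.23 log units; within the scatter) is expected, which rests on compound 3 at 9530 nM and on the measured step of an at least 1.4-fold higher number from compound 1 to compound 2 (0.17 log units; that floor lies within the scatter). Compound 4 is thus estimated at 16000 nM in this assay, within 7000 nM to 40000 nM, most likely reported only as a limit.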

Compound 4, concentration for 50% growth inhibition: > 10000 nM
Compound 4 ended at the assay's limit; the forecaster's own chance of this, stated with the estimate: 70%; the middle value does not contradict the limit.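

In this assay compound 4 gives > 10000 nM, which is a limit of the assay and not a number. The step on the core of compound 3 is therefore only a floor, an at least 1.0-fold higher number from compound 3 to compound 4 (0.02 log units; that floor lies within the scatter), so the data show nothing against phenyl in place of methoxy on an aromatic carbon carrying over from one core to the other, but they do not establish its size on either core. Whether the change has the same size on both cores remains unresolved, and the comparison stands as follows: the same change on two cores in this assay, an at least 1.4-fold higher number (0.17 log units; that floor lies within the scatter) from compound 1 to compound 2 and an at least 1.0-fold higher number (0.02 log units; that floor lies within the scatter) from compound 3 to compound 4; the limit leaves it open whether they differ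

As far as these compounds go, with both phenyl compounds reported only as limits, the series gives no measured size for this change: the limit of > 10000 nM in this assay, at which 2 of the 4 values shown sit. It is also open whether another group at this place, such as an amine, a carboxylic acid or a longer chain, would give numbers within the range of the assay on both cores and so allow the two cores to be compared directly.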